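Swapping an aminophenyl arm for a methanesulfonamido group

The source may hold more compounds than are shown below. What is called first, only, known or untested is meant among the compounds shown, and "the series" means these compounds.

Measured so far:
- Compound 1, `O=S(=O)(c1cccc(-c2ccc3nccc(-c4ccncc4)c3n2)c1)N1CCC(O)CC1`: 7%
- Compound 2, `Nc1cccc(-c2ccc3nccc(-c4ccncc4)c3n2)c1`: 54%

In an ADME assay on microsomes from liver (Mus musculus) for metabolic stability, read by LC-MS, using NADPH, with a stated time of 30 min, tested at 0.1 uM (a higher number here means that more of the compound is left, a lower number that less of the compound is left), compound 2 stands highest of the two numbers; its nearest neighbour is compound 1, and the step of a number 47 percentage points higher from compound 1 to compound 2 (beyond the scatter) lies well beyond the scatter. Compound 3, `CS(=O)(=O)Nc1ccc2nccc(-c3ccncc3)c2n1`, has not been measured. It differs from compound 2 by methanesulfonamido in place of 3-aminophenyl on an aromatic carbon. Among the compounds with values here, only the step from compound 1 to compound 2 bears on this change, and only loosely, since it swaps groups on the same phenyl ring rather than removing the ring. A modest downward step is therefore expected, a number 12 percentage points lower from compound 2 to compound 3 (beyond the scatter), with wide uncertainty. Compound 3 is estimated at 42%, within 12% to 78%.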

Compound 3, percent of the compound remaining: 95%
The estimate for compound 3 lay 53 percentage points below the measured number, outside the stated range (above it).
By their numbers in this assay, from the lowest: compound 1; then compound 2; then compound 3.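

In this assay there is a number 41 percentage points higher from compound 2 to compound 3 (beyond the scatter) when methanesulfonamido replaces the whole 3-aminophenyl arm. The earlier step changed only a group on that phenyl ring, whereas this one shows that the position next to the ring nitrogen can carry a group with no ring at all and give the highest number of the three compounds. Nothing measured here explains the rise.

Still open, going by these compounds, is whether losing the ring or gaining the sulfonamide matters more. An amine or an acetamide at this position would help separate the two.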